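This account rests on a few compounds, and the source may have more. Where it says the series, first, only, none or still open, it means among the compounds named here.

Three compounds built on a shared core have numbers in an ADME assay on LLC-MK2 cells (Macaca mulatta) for cytotoxicity, read by MTT assay, with a stated time of 48 h; on this read-out lower numbers stand for higher toxicity in this test and higher numbers for lower toxicity in this test: compound 1 (`COc1ccc(/C=C/C(=O)/C(C)=C/c2ccccc2)cc1`) gives 93000 nM, compound 2 (`C/C(=C\c1ccccc1)C(=O)/C=C/c1ccc([N+](=O)[O-])cc1`) gives 43300 nM, and compound 3 (`C/C(=C\c1ccccc1)C(=O)/C=C/c1ccc(N(C)C)cc1`) gives 53000 nM. Compound 2 therefore sits level with compound 3 and only modestly under compound 1. The next compound, compound 4 (`COc1ccc(/C=C(\C)C(=O)/C=C/c2ccc([N+](=O)[O-])cc2)cc1`), differs from compound 2 by a single change: methoxy in place of hydrogen on an aromatic carbon.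

For the measured compounds named here, no measured step makes exactly this swap. The closest evidence comes from exchanges among methoxy, nitro and dimethylamino on an aromatic carbon, and none of them is large: a 2.1-fold lower number from compound 1 to compound 2 (0.33 log units; beyond the scatter), a 1.8-fold lower number from compound 1 to compound 3 (0.24 log units; within the scatter) and a 1.2-fold higher number from compound 2 to compound 3 (0.09 log units; within the scatter). A similarly small shift is therefore expected in this assay, with no firm direction and probably none beyond the scatter. The estimated change is a 1.2-fold higher number from compound 2 to compound 4 (0.06 log units; within the scatter). Compound 4 is expected at about 50000 nM, with an estimated range of 23000 nM to 105000 nM.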

Compound 4, half-maximal cytotoxic concentration: 20100 nM
The estimate for compound 4 lay 2.5-fold (0.40 log units) above the measured number; the measured number lies below the stated range.
By their numbers in this assay, from the lowest: compound 4; then compounds 2, 3 and 1 (each within the scatter of the next, the first and the last beyond it).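

Going from phenyl to 4-methoxyphenyl in this assay gives a 2.2-fold lower number from compound 2 to compound 4 (0.33 log units; beyond the scatter), a modest step but one beyond the scatter, and it points towards higher toxicity in this test. For the compounds shown here, the earlier compounds all kept plain phenyl at this end and differed only in a group elsewhere, so this is the first sign that a substituent at this place, para to a large group, can shift the number. Nothing available here accounts for the shift.

Going by these compounds, this is a single pair carrying nitro, so it remains open whether methoxy at this place would act alike in compounds with methoxy or dimethylamino at the other end. Also open, on these data alone, is how a different group here, such as a hydroxyl, a fluorine atom or a carboxylic acid, would compare.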